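Stability of Compound 3 Estimated from Compound 2

This account rests on a few compounds, and the source may have more. Where it says the series, first, only, none or still open, it means among the compounds named here.

Measured so far:
compound 1, `CC(=O)NCCC(CC(=O)Nc1ccc(C)cc1C)c1nnc(CCCC(C)C)n1C1CC1`: 39%
compound 2, `Cc1ccc(NC(=O)C[C@H](CCC(=O)O)c2noc(-c3ccc(CC(C)C)cc3)c2C2CC2)c(Cl)c1`: 80%

In an ADME assay on microsomes from liver (Homo sapiens) for metabolic stability, with a stated time of 60 min (on this read-out higher numbers stand for a more stable compound and lower numbers for a less stable compound), compound 2 gives 80%, the higher of the two numbers recorded. In this assay compound 1 gives 39%, and the gap between compound 1 and compound 2 lies beyond the scatter, so compound 2 stands clearly as the more stable of the two.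

Compound 3, `Cc1ccc(NC(=O)C[C@H](CCC(=O)O)c2noc(-c3cc(C(F)(F)C(C)C)on3)c2C2CC2)c(Cl)c1`, has not yet been measured. It differs from compound 2 in one place: 5-(1,1-difluoro-2-methylpropyl)-1,2-oxazol-3-yl in place of 4-isobutylphenyl on an aromatic carbon. Within the data shown here, no pair of measured compounds shows the effect of this kind of change, so there is no measured step to lean on.

The account therefore expects for compound 3 a number near that of compound 2, because compound 2 gives 80% and the step expected from compound 2 to compound 3 is a number 6 percentage points lower from compound 2 to compound 3 (within the scatter), not beyond the scatter. Compound 3 is thus estimated at 74% in this assay, within the range 55% to 92%.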

Compound 3, percent of the compound remaining: 74%
Compound 3: middle estimate and measured number agree at the digits printed; low and high end bracket the measured number.
By their numbers in this assay, from the lowest: compound 1; then compounds 3 and 2 (each within the scatter of the next).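

In this assay, among these compounds, 5-(1,1-difluoro-2-methylpropyl)-1,2-oxazol-3-yl in place of 4-isobutylphenyl gives a number 6 percentage points lower from compound 2 to compound 3 (within the scatter), the first measured step at this position, so the two compounds cannot be told apart on this read-out. This place, on an aromatic carbon next to the ring oxygen, therefore accepts a five-membered aromatic ring with 2 hetero atoms and 2 hydrogen-bond acceptors in place of a six-membered aromatic ring of carbon only, with no step beyond the scatter. Nothing measured here bears on the reason for this result.

The step exchanges the ring and its side chain together, so the share of each cannot be read from these compounds. Also open, as far as these compounds go, is how this place would respond to a smaller substituent, such as a nitrile, or to one carrying an amine.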